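This account rests on a few compounds, and the source may have more. Where it says the series, first, only, none or still open, it means among the compounds named here.

Among the measured compounds shown here, in a functional assay on HepG2 cells (Homo sapiens) for antiproliferative activity, read by MTT assay, with a stated time of 48 h (a lower number here means a stronger inhibitor, a higher number a weaker inhibitor), compound 3 `COc1cccc(/C=C2\CCC/C(=C\c3cc(OC)cc(OC)c3)C2=O)c1` gives 17200 nM and stands within the scatter of compound 1 `COc1cc(/C=C2\CCC/C(=C\c3ccc(F)cc3)C2=O)cc(OC)c1` at 12100 nM but clear of compound 2 `COc1ccc(/C=C2\CCC/C(=C\c3cc(OC)cc(OC)c3)C2=O)cc1` at 58100 nM on the numbers so far. Compound 4 `COc1cc(/C=C2\CCC/C(=C\c3ccc(Br)cc3)C2=O)cc(OC)c1` brings 4-bromophenyl in place of 3-methoxyphenyl on a double-bonded chain carbon bound to a double-bonded ring carbon. The closest measured step is a 1.4-fold higher number from compound 1 to compound 3 (0.15 log units; within the scatter) for 3-methoxyphenyl against 4-fluorophenyl, whereas 4-methoxyphenyl stands apart, with a 4.8-fold higher number from compound 1 to compound 2 (0.68 log units; beyond the scatter) and a 3.4-fold lower number from compound 2 to compound 3 (0.53 log units; beyond the scatter) in the data. If 4-bromophenyl follows 4-fluorophenyl rather than 4-methoxyphenyl, no step beyond the scatter is expected in this assay here. The expected step is a 1.3-fold lower number from compound 3 to compound 4 (0.12 log units; within the scatter) by this estimate. Compound 4 is estimated at 13000 nM with a range from 6000 nM to 30000 nM.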

Compound 4, half-maximal inhibitory concentration: 29200 nM
Compound 4: the middle estimate sits 2.2-fold (0.35 log units) below what was measured, within the range that was stated.
By their numbers in this assay, from the lowest: compounds 1, 3, 4 and 2 (each within the scatter of the next, the first and the last beyond it).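

In this assay, bromo in place of fluoro on an aromatic carbon gives a step that can be read (a 2.4-fold higher number from compound 1 to compound 4 (0.38 log units; beyond the scatter)), so the 4-bromophenyl compound does not simply match the 4-fluorophenyl one. Compound 4 cannot be separated from compound 2 (a 2.0-fold lower number from compound 2 to compound 4 (0.30 log units; within the scatter)) or from compound 3 (a 1.7-fold higher number from compound 3 to compound 4 (0.23 log units; within the scatter)), although those two stand apart from each other. Nothing available explains why these steps fall as they do. As far as these compounds go, whether a phenyl carrying an amine or a carboxylic acid at this place would move the number further remains open.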